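The source may hold more compounds than are shown below. What is called first, only, known or untested is meant among the compounds shown, and "the series" means these compounds.

Measured so far:
compound 1 `COc1cc(-c2cc(/C=C/C(=O)c3ccc(Cl)c(Cl)c3)[nH]n2)cc(OC)c1OC`: 19%
compound 2 `COc1ccc(-c2cc(/C=C/C(=O)c3cc(OC)c(OC)c(OC)c3)[nH]n2)cc1OC`: -81%

In a functional assay on KM12 cells (Homo sapiens) for cytotoxicity, read by sulforhodamine B assay, with a stated time of 48 h, tested at 10 uM (on this read-out higher numbers stand for a weaker effect at the one concentration tested and lower numbers for a stronger effect), compound 1 gives 19%, the higher of the two numbers; compound 2 gives -81%, a gap well beyond the scatter. Compound 3 `COc1cc(-c2cc(/C=C/C(=O)c3ccc(F)c(F)c3)[nH]n2)cc(OC)c1OC` is not yet measured. It differs from compound 1 by 3,4-difluorophenyl in place of 3,4-dichlorophenyl on a carbonyl carbon. Within the data shown here, no measured pair shows this change, so the step from compound 1 to compound 3 is expected to be small, at most a modest shift toward a weaker effect, a number 11 percentage points higher from compound 1 to compound 3 (beyond the scatter). Compound 3 is accordingly expected to give 30%, with a range from -10% to 70%.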

Compound 3, a percentage reported as activity, at one concentration (the size of the read-out at that concentration, not a potency): 3%
For compound 3 the middle estimate is 27 percentage points above the measured one; measured number inside the range.
By their numbers in this assay, from the lowest: compound 2; then compound 3; then compound 1.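

In this assay, among these compounds, 3,4-difluorophenyl in place of 3,4-dichlorophenyl on a carbonyl carbon gives a number 16 percentage points lower from compound 1 to compound 3 (beyond the scatter), the only one-place comparison so far. This position therefore responds to an exchange of the two halogens, with the lower number marking a stronger effect for compound 3. No available measurement accounts for this step.

On these data alone, it remains open how a phenyl ring carrying an amine or a carboxylic acid would read at this position. As far as these compounds go, whether the same exchange gives a similar step on other cores also remains open.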